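Shrinking the Piperazine Substituent From Pyrazinyl to Methyl

The compounds below may be only part of what the source reports. "The series", "measured", "known", "first", "only" and "open" are said of these compounds alone.

Of the compounds shown here, three sharing one core have been measured in a functional assay on A-375 cells (Homo sapiens) for antiproliferative activity, read by CCK-8 assay, with a stated time of 72 h, tested at 2 uM; on this read-out higher numbers stand for a stronger effect at the one concentration tested and lower numbers for a weaker effect. Compound 1 `Nc1ccccc1NC(=O)c1ccc(CSC(=S)N2CCN(Cc3ccccn3)CC2)cc1` gives 20.7%. Compound 2 `Nc1ccccc1NC(=O)c1ccc(CSC(=S)N2CCN(Cc3ccncc3)CC2)cc1` gives 33.1%. Compound 3 `Nc1ccccc1NC(=O)c1ccc(CSC(=S)N2CCN(c3cnccn3)CC2)cc1` gives 29.1%, which places it second highest of the three, though its gap to compound 2 and its gap to compound 1 both lie within the scatter. The step from compound 1 to compound 2 was a number 12.4 percentage points higher from compound 1 to compound 2 (beyond the scatter). The steps of a number 8.4 percentage points higher from compound 1 to compound 3 (within the scatter) and a number 4 percentage points lower from compound 2 to compound 3 (within the scatter) show that swapping the group on the ring nitrogen has so far moved the read-out only within the scatter.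

Compound 4 `CN1CCN(C(=S)SCc2ccc(C(=O)Nc3ccccc3N)cc2)CC1` differs from compound 3 in one place: methyl in place of pyrazin-2-yl on an amine nitrogen in a ring. Within the data shown here, no measured step covers this exact exchange, but the two steps ending at compound 3 bear on the same position and were small. Compound 4 is therefore expected to show a step of a number 4.1 percentage points lower from compound 3 to compound 4 (within the scatter), no larger than the scatter, with a slight lean downward. Compound 4 is estimated at 25%, in a range from 10% to 40%.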

Compound 4, a percentage reported as inhibition, at one concentration (the size of the read-out at that concentration, not a potency): 36.6%
The estimate for compound 4 lay 11.6 percentage points below the measured number, within the range that was stated.
By their numbers in this assay, from the lowest: compounds 1, 3, 2 and 4 (each within the scatter of the next, the first and the last beyond it).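

In this assay this position on the ring amine nitrogen holds a group as small as methyl, one carbon in place of the six heavy atoms and aromatic ring of pyrazin-2-yl, with a number 7.5 percentage points higher from compound 3 to compound 4 (within the scatter) for that exchange and a number 3.5 percentage points higher from compound 2 to compound 4 (within the scatter) for hydrogen in place of pyridin-4-yl on the saturated chain carbon. Only hydrogen in place of pyridin-2-yl at that carbon gives a step beyond the scatter, a number 15.9 percentage points higher from compound 1 to compound 4 (beyond the scatter) and so an aromatic ring on this nitrogen is not needed for a read-out of this size. No measured evidence accounts for these steps.

Going by these compounds, whether a bare ring nitrogen bearing only hydrogen, an acetyl group or a longer chain such as propyl would read the same stays open. A single tested concentration also leaves the potency of all four compounds unknown.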